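A new group on the carbonyl of compound 3

The source may hold more compounds than are shown below. What is called first, only, known or untested is meant among the compounds shown, and "the series" means these compounds.

Measured so far in a functional assay on MCF7 cells (Homo sapiens) for antiproliferative activity, read by MTT assay, with a stated time of 72 h; a higher number here means a weaker inhibitor, a lower number a stronger inhibitor:
- compound 1 `CCn1c(C(=O)NCc2ccc(OC)cc2)ccc1C(CC)(CC)c1ccc(C#CC(O)(CC)CC)c(C)c1`: > 50000 nM
- compound 2 `C#CCCOC(=O)c1ccc(C(CC)(CC)c2ccc(C#CC(O)(CC)CC)c(C)c2)n1CC`: > 50000 nM
- compound 3 `CCn1c(C(=O)On2nnc3ccccc32)ccc1C(CC)(CC)c1ccc(C#CC(O)(CC)CC)c(C)c1`: > 50000 nM

Each of these entries is a limit of the assay and not a number. Compound 3 stands at > 50000 nM, which is such a limit. The whole set sits together: the limit of > 50000 nM in this assay, at which 3 of the 3 values shown sit.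

Compound 4 `CCn1c(C(=O)NCC(=O)O)ccc1C(CC)(CC)c1ccc(C#CC(O)(CC)CC)c(C)c1` keeps the shared core and changes only the group on a carbonyl carbon: a group of 5 heavy atoms (2 carbon, 1 nitrogen, 2 oxygen; no ring) in place of a group of 10 heavy atoms (6 carbon, 3 nitrogen, 1 oxygen; one five-membered aromatic ring with 3 hetero atoms, one six-membered aromatic ring of carbon only), on a carbonyl carbon. The group that enters is (carboxymethyl)amino, which has no ring.

Within the data shown here, three measured steps bear on this change, as each alters the group at this end of the molecule: a step that the two limits leave unreadable from compound 1 to compound 2, a step that the two limits leave unreadable from compound 1 to compound 3 and a step that the two limits leave unreadable from compound 2 to compound 3. None of them has a readable size, so they offer no measured shift to carry over. A gain in this assay is not expected, so the estimated step is a number no higher from compound 3 to compound 4 (the limit leaves the size open). The assay will most likely report only a limit again. Compound 4 is expected near 50000 nM, with an estimated range of 20000 nM to 100000 nM.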

Compound 4, half-maximal inhibitory concentration: 5140 nM
The estimate for compound 4 lay 9.7-fold (0.99 log units) above the measured number, and the stated range ends above it.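

In this assay, compound 4 alone gives a number and not a limit, so the group on this carbonyl carbon can decide whether the shared core shows a measurable effect here, while the other compounds sit together: the limit of > 50000 nM in this assay, at which 3 of the 4 values shown sit.

From the compounds shown here alone, the change reads as an at least 9.7-fold lower number from compound 3 to compound 4 (0.98 log units; beyond the scatter), as an at least 9.7-fold lower number from compound 2 to compound 4 (0.98 log units; beyond the scatter) and as an at least 9.7-fold lower number from compound 1 to compound 4 (0.98 log units; beyond the scatter); each of these steps starts from a limit, so its full size stays open. Compound 1 and compound 4 share the amide-type nitrogen, so carboxy in place of 4-methoxyphenyl on the saturated chain carbon is enough for this shift.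

Going by these compounds, whether the carboxy end alone carries the effect remains open. An amine or a methyl ester in its place, or a longer chain leading to the carboxy, would help to answer that.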